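Sulfamoylphenyl in place of difluorophenyl on the shared core

This account rests on a few compounds, and the source may have more. Where it says the series, first, only, none or still open, it means among the compounds named here.

Measured so far:
compound 1 `O=C(O)Cc1sc(CSc2ccccc2)nc1-c1ccc(Cl)cc1` — 450 nM
compound 2 `O=C(O)Cc1sc(C(c2ccccc2)c2ccccc2)nc1-c1ccccc1` — 370 nM
compound 3 `O=C(O)Cc1sc(C(c2ccc(F)cc2)c2ccc(F)cc2)nc1-c1cc(F)cc(F)c1` — 340 nM

In an in vitro functional assay on HEK285-7 cells for antagonist activity at prostaglandin D2 receptor 2 (Homo sapiens), read by BRET and beta-arrestin recruitment (a lower number here means a stronger inhibitor, a higher number a weaker inhibitor), compound 3 gives 340 nM, the lowest of the three numbers; compound 2 gives 370 nM and compound 1 gives 450 nM, both within the scatter of compound 3, so no order among the three can be read from this assay. The three share a core that carries a carboxymethyl group and differ in the groups on the two aromatic carbons; none of these exchanges moves the number beyond the scatter.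

Compound 4 `NS(=O)(=O)c1cccc(-c2nc(C(c3ccc(F)cc3)c3ccc(F)cc3)sc2CC(=O)O)c1` differs from compound 3 in one place: 3-sulfamoylphenyl in place of 3,5-difluorophenyl on an aromatic carbon. For the measured compounds named here, no directly measured step covers an exchange of this kind, so the expectation rests on the flatness of the three numbers. Compound 4 is expected to stay close to compound 3, with a step from compound 3 to compound 4 of a 1.1-fold lower number from compound 3 to compound 4 (0.05 log units; within the scatter), not beyond the scatter in either direction. For compound 4 the estimate in this assay is 300 nM, with a range from 100 nM to 900 nM.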

Compound 4, half-maximal inhibitory concentration: 710 nM
Beside the measured number, compound 4's estimate is 2.4-fold (0.37 log units) below it, and the stated range covers the measured number.
By their numbers in this assay, from the lowest: compounds 3, 2, 1 and 4 (each within the scatter of the next, the first and the last beyond it).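

In this assay, 3-sulfamoylphenyl in place of 3,5-difluorophenyl gives a 2.1-fold higher number from compound 3 to compound 4 (0.32 log units; beyond the scatter) as the only single-place step shown, and it lies beyond the scatter, though modestly. The aromatic carbon next to the ring nitrogen is therefore not indifferent to the group it carries, yet it tolerates a group with a hydrogen-bond donor and acceptors in place of one with neither, at a modest cost in this read-out. Nothing shown accounts for this step.

The exchange removes both fluorines and adds the sulfamoyl group in one move, so the shift cannot be assigned to either change alone. On these data alone, it also remains open whether a primary amide or an amine on the same phenyl ring would give a number like that of compound 3 or like that of compound 4.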